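The source may report more compounds than this note shows. Statements on the series, on what has been measured and on what is new or still open speak of the compounds shown alone.

Measured compounds in an ADME assay on MT2 cells (Homo sapiens) for cytotoxicity; a lower number here means that less compound is tolerated, a higher number that more compound is tolerated:

Compound 1, `Cc1nc2cc(C(=O)NCc3ccc(F)cc3)nn2c(-c2cc(F)c3c(c2C)CCCO3)c1[C@H](OC(C)(C)C)C(=O)O`. In this assay compound 1 gives > 40000 nM, which is a limit of the assay and not a number.
Compound 2, `Cc1cc(CNC(=O)c2cc3nc(C)c([C@H](OC(C)(C)C)C(=O)O)c(-c4cc(F)c5c(c4C)CCCO5)n3n2)ccc1F`. In this assay compound 2 gives > 40000 nM, again a limit.
Compound 3, `CCc1cc(CNC(=O)c2cc3nc(C)c([C@H](OC(C)(C)C)C(=O)O)c(-c4cc(F)c5c(c4C)CCCO5)n3n2)ccc1F`. In this assay compound 3 gives > 40000 nM, likewise a limit.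

For the measured compounds named here, compound 3 therefore stands at a limit, and the two further values shown are limits as well, so no compound can be ranked against another: the limit of > 40000 nM in this assay, at which 3 of the 3 values shown sit.

Compound 4 is `CCCc1cc(CNC(=O)c2cc3nc(C)c([C@H](OC(C)(C)C)C(=O)O)c(-c4cc(F)c5c(c4C)CCCO5)n3n2)ccc1F`. It differs from compound 3 by methyl in place of hydrogen on a saturated chain carbon, two bonds along the chain from an aromatic carbon.

The step closest in kind, a step that the two limits leave unreadable from compound 2 to compound 3, adds a carbon on the same chain, and a step that the two limits leave unreadable from compound 1 to compound 2 and a step that the two limits leave unreadable from compound 1 to compound 3 add the whole chain; all three sit between two limits, so none reveals a size or a direction. No readable step bears on the change, so nothing beyond the scatter is expected, and the step that the limit leaves unreadable from compound 3 to compound 4 is simply the estimate.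

Compound 4 is expected to give 60000 nM, within 30000 nM to 150000 nM.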

Compound 4, half-maximal cytotoxic concentration: > 20000 nM
Compound 4: only a limit was reported; the forecaster's own chance of this, stated with the estimate: 85%; the middle value does not contradict the limit.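

In this assay compound 4 gives > 20000 nM, a limit of the assay and not a number. Its steps from compound 1, compound 2 and compound 3 all join two limits and cannot be read. The compounds shown leave open whether methyl, ethyl or propyl changes the half-maximal cytotoxic concentration at all.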